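The compounds below may be only part of what the source reports. "The series", "measured", "known", "first", "only" and "open" are said of these compounds alone.

Working notes on the series. Compound 2 `COc1ccc(COc2ccc3c(Cn4ccnc4)cc(=O)oc3c2)cc1` in an assay for inhibition of steroid 17-alpha-hydroxylase/17,20 lyase (Homo sapiens), read by HPLC, with a stated time of 5 min, tested at 2.5 uM, in the presence of a further agent that is not named here (on this read-out lower numbers stand for less inhibition and higher numbers for more inhibition at the one concentration tested (going by the name of the read-out)), gives 1%. On the numbers shown compound 2 stands highest of three, yet no step separates it from the others beyond the scatter: compound 1 `COc1ccc(COc2ccc3c(Cn4ccnc4)cc(=O)oc3c2)cc1OC` in this assay gives 0%, and compound 3 `O=c1cc(Cn2ccnc2)c2ccc(OCc3cccc(F)c3)cc2o1` in this assay gives 0%. The two measured steps are a number 1 percentage points higher from compound 1 to compound 2 (within the scatter) and a number 1 percentage points lower from compound 2 to compound 3 (within the scatter); both are flat and both concern changes at other places than the one now in question.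

Compound 4 `CCCOc1ccc(COc2ccc3c(Cn4ccnc4)cc(=O)oc3c2)cc1` differs from compound 2 by ethyl in place of hydrogen on a saturated chain carbon bound to an oxygen on an aromatic ring. Among the compounds with values here, no measured step tests this exact change, so the expectation rests only on the flat picture across compounds 1, 2 and 3, where neither removal of a methoxy on an aromatic carbon nor exchange of the aryl group moved this assay. The step of a number 1 percentage points higher from compound 2 to compound 4 (within the scatter) is therefore expected to be none beyond the scatter. Compound 4 in this assay is estimated at 2%, within a range of 0% to 12%.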

Compound 4, a percentage reported as inhibition, at one concentration (the size of the read-out at that concentration, not a potency): 2%
Compound 4: the middle estimate sits on the measured number at the digits printed, and the stated range covers the measured number.
By their numbers in this assay, from the lowest: compounds 1, 3, 2 and 4 (each within the scatter of the next).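

Methoxy to propoxy, the first change at this place, gives a number 1 percentage points higher from compound 2 to compound 4 (within the scatter) in this assay and so extends the flat picture from the aromatic substituents and the aryl group to the chain on the oxygen. Ethyl in place of hydrogen on a saturated chain carbon bound to an oxygen on an aromatic ring adds bulk of two carbons without a step beyond the scatter, and compounds 1, 3, 2 and 4 each stay within the scatter of the next. Nothing available explains this flatness.

The compounds shown leave open whether this place is truly indifferent or whether the whole series lies too low in this read-out for any change to register. A longer chain such as hexyloxy, or a terminal amine or carboxylic acid on the chain, would be a sharper test of that question.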